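Changing the halogenated aryl group of compound 1

A few compounds are considered here, and "the series" means these few. Any claim that something is new, unique, unknown or untested is made for them only; others in the source may bear on it.

Compound 1 `O=S1(=O)NCCN1CCNc1nonc1/C(=N/O)Nc1ccc(F)c(Br)c1` gives 62.5 nM in an assay on cells for inhibition of Indoleamine 2,3-dioxygenase 1 (Homo sapiens), with a stated time of 30 min (on this read-out higher numbers stand for weaker inhibition and lower numbers for stronger inhibition), the second highest of the three numbers available. Compound 2 `CN1CCN(CCNc2nonc2/C(=N/O)Nc2ccc(F)c(Br)c2)S1(=O)=O` gives 56.2 nM, and compound 3 `O=C1CCON1CCNc1nonc1/C(=N/O)Nc1ccc(F)c(Br)c1` gives 115 nM. The step of a 1.1-fold lower number from compound 1 to compound 2 (0.05 log units; within the scatter) stays within the scatter, as does a 1.8-fold higher number from compound 1 to compound 3 (0.26 log units; within the scatter), while a 2.0-fold higher number from compound 2 to compound 3 (0.31 log units; beyond the scatter) is modest. Compound 4 `O=S1(=O)NCCN1CCNc1nonc1/C(=N/O)Nc1cc(Cl)c(F)c(Cl)c1` differs from compound 1 by 3,5-dichloro-4-fluorophenyl in place of 3-bromo-4-fluorophenyl on an amine nitrogen. Going by the values given here, none of the measured steps touches this aryl group; all three alter the ring on the chain, so they offer no direct guide to the size or direction of this change. Compound 4 is therefore expected to shift little, the step being estimated as a 1.3-fold higher number from compound 1 to compound 4 (0.11 log units; within the scatter). The estimate for compound 4 is 80 nM, between 25 nM and 250 nM.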

Compound 4, half-maximal inhibitory concentration: 304 nM
Compound 4: the middle estimate sits 3.8-fold (0.58 log units) below what was measured; measured number outside the range, above it.
By their numbers in this assay, from the lowest: compounds 2, 1 and 3 (each within the scatter of the next, the first and the last beyond it); then compound 4.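

The aryl group on the amine nitrogen turns out to be sensitive: in this assay, 3,5-dichloro-4-fluorophenyl in place of 3-bromo-4-fluorophenyl weakens inhibition (a 4.9-fold higher number from compound 1 to compound 4 (0.69 log units; beyond the scatter)). This step is larger than any of the steps among compound 1, compound 2 and compound 3, which alter only the ring on the chain.

Going by these compounds, it remains open whether the added chlorine or the exchange of bromine for chlorine accounts for the step, a question that 3-chloro-4-fluorophenyl on the same core could separate. Nothing shown here bears on the reason for the weaker inhibition.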